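A few compounds are considered here, and "the series" means these few. Any claim that something is new, unique, unknown or untested is made for them only; others in the source may bear on it.

Working notes on the sulfur-substituted series. Compound 1 `CC(C)c1n[nH]c2c(NCc3ccc(-c4ccccn4)cc3)nc(SCC(O)CO)nc12` gives 21 nM in a functional assay on HT cells (Homo sapiens) for antiproliferative activity, read by fluorescence, with a stated time of 72 h (on this read-out lower numbers stand for stronger inhibition of growth and higher numbers for weaker inhibition of growth), the lowest of the three numbers in hand, and its steps to both other measured compounds lie beyond the scatter. Compound 2 `CC(C)c1n[nH]c2c(NCc3ccc(-c4ccccn4)cc3)nc(SC(C)C(C)O)nc12` gives 190 nM in this assay and compound 3 `CC(C)c1n[nH]c2c(NCc3ccc(-c4ccccn4)cc3)nc(SCCCN(C)C)nc12` gives 105 nM; the step of a 9.0-fold higher number from compound 1 to compound 2 (0.96 log units; beyond the scatter) and the step of a 5.0-fold higher number from compound 1 to compound 3 (0.70 log units; beyond the scatter) both run the same way, whereas a 1.8-fold lower number from compound 2 to compound 3 (0.26 log units; within the scatter) stays within the scatter. Compound 4 `CC(C)c1n[nH]c2c(NCc3ccc(-c4ccccn4)cc3)nc(SCC(C)(C)O)nc12` differs from compound 1 by 1-hydroxy-1-methylethyl in place of 1,2-dihydroxyethyl on a saturated chain carbon bound to a sulfur. Both measured departures from the 2,3-dihydroxypropyl group of compound 1 raised the number in this assay; compound 4 keeps one hydroxyl, so a rise smaller than a 9.0-fold higher number from compound 1 to compound 2 (0.96 log units; beyond the scatter) but of the same sign as a 5.0-fold higher number from compound 1 to compound 3 (0.70 log units; beyond the scatter) is expected, and the two steps do not support a step within the scatter. Compound 4 is therefore estimated at 60 nM with a range of 25 nM to 150 nM, that is, an expected step of a 2.9-fold higher number from compound 1 to compound 4 (0.46 log units; beyond the scatter).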

Compound 4, concentration for 50% growth inhibition: 507 nM
Compound 4: middle estimate off by 8.5-fold (0.93 log units), on the low side; the whole stated range lies below it.
By their numbers in this assay, from the lowest: compound 1; then compounds 3 and 2 (each within the scatter of the next); then compound 4.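

In this assay, a 24-fold higher number from compound 1 to compound 4 (1.38 log units; beyond the scatter) is the largest step yet seen on the sulfur, so a hydroxyl retained on this chain does not by itself preserve the low number of compound 1. The change from 2-hydroxy-1-methylpropyl to 2-hydroxy-2-methylpropyl also matters, giving a 2.7-fold higher number from compound 2 to compound 4 (0.43 log units; beyond the scatter), and the hydroxyl-bearing chain of compound 4 does worse than the 3-(dimethylamino)propyl chain, with a 4.8-fold higher number from compound 3 to compound 4 (0.68 log units; beyond the scatter), so a hydroxyl does not rank above a dimethylamino group across these chains. No measurement in hand gives a reason for this order.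

Without an unbranched 2-hydroxyethyl or 3-hydroxypropyl chain on the sulfur, the share of the rise tied to the loss of the 2,3-dihydroxypropyl group and the share tied to the added methyl branching cannot be separated. From the compounds shown here alone, a carboxylic acid or a primary amine at the end of the chain also remains open.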